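This account rests on a few compounds, and the source may have more. Where it says the series, first, only, none or still open, it means among the compounds named here.

Measured in an ADME assay on microsomes from liver (Mus musculus, strain CD1) for metabolic stability; a higher number here means that the compound lasts longer, a lower number that the compound disappears faster:
- compound 1 `COc1cc(N2C(=O)C3(CCC3)N(c3ccc(OC4CCN(C)CC4)nc3)C2=S)cnc1C#N`: 2.25 h
- compound 2 `CN1CCC(Oc2ccc(N3C(=S)N(c4cnc(C#N)c(C(F)(F)F)c4)C(=O)C34CCC4)cn2)CC1`: 2.88 h
- compound 3 `Cc1cc(N2C(=O)C3(CCC3)N(c3ccc(OC4CCNCC4)nc3)C2=S)cnc1C#N`: > 3 h

For compound 3, > 3 h is a limit and not a number. Compound 4 `N#Cc1ncc(N2C(=O)C3(CCC3)N(c3ccc(OC4CCNCC4)nc3)C2=S)cc1C(F)(F)F` carries trifluoromethyl in place of methyl on an aromatic carbon, ortho to a cyano group: trifluoromethyl in place of methyl on an aromatic carbon. Going by the values given here, one measured step bears on this indirectly, since trifluoromethyl there replaces methoxy rather than methyl: a 1.3-fold higher number from compound 1 to compound 2 (0.11 log units; within the scatter). On that step, no change beyond the scatter is expected in this assay. The expected step is a number no higher from compound 3 to compound 4 (the limit leaves the size open). For compound 4 the estimated half-life is 3 h, with an expected range of 1.8 h to 4.5 h.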

Compound 4, half-life: > 3 h
Compound 4 was reported as a limit; the forecaster's own chance of this, stated with the estimate: 55%; the middle value sits exactly at the limit.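

In this assay compound 4 gives > 3 h, a limit and not a number. Trifluoromethyl in place of methyl on this aromatic carbon, ortho to a cyano group, cannot be read as a step, because compound 3 and compound 4 share that limit: the limit of > 3 h in this assay, at which 2 of the 4 values shown sit. Hydrogen in place of methyl on an amine nitrogen in a ring gives an at least 1.0-fold higher number from compound 2 to compound 4 (0.01 log units; that floor lies within the scatter).

On these data alone, how far compound 3 and compound 4 each lie past the limit stays open. As far as these compounds go, how a chlorine or a primary amine on this aromatic carbon would read in this assay also remains open.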